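The source may report more compounds than this note shows. Statements on the series, on what has been measured and on what is new or still open speak of the compounds shown alone.

Working notes on the series, read in a functional assay on HT-29 cells (Homo sapiens) for inhibition, read by MTT assay, with a stated time of 48 h; a lower number here means a stronger inhibitor, a higher number a weaker inhibitor. Compound 1 (`COc1cc(-c2nnc(SCc3ccc(C)cc3)n2-c2ccc(N(C)C)cc2)cc(OC)c1OC`) gives 27500 nM, compound 2 (`COc1cc(-c2nnc(SCc3ccc(F)cc3)n2-c2ccc(N(C)C)cc2)cc(OC)c1OC`) gives 44300 nM, and compound 3 (`COc1cc(-c2nnc(SCC(=O)c3ccccc3)n2-c2ccc(N(C)C)cc2)cc(OC)c1OC`) gives 45200 nM. Compound 3 stands within the scatter of both other compounds, so the three cannot be ranked. Compound 4 (`COc1cc(-c2nnc(SCC(=O)c3ccc(F)cc3)n2-c2ccc(N(C)C)cc2)cc(OC)c1OC`) differs from compound 3 by one change: fluoro in place of hydrogen on an aromatic carbon. This is fluoro in place of hydrogen on an aromatic carbon, taking benzoyl to (4-fluorophenyl)carbonyl. Within the data shown here, no measured pair shows this exact change. The closest evidence is the step of a 1.6-fold higher number from compound 1 to compound 2 (0.21 log units; within the scatter), with fluoro in place of methyl on an aromatic carbon. The two steps that alter the group on the saturated chain carbon, a 1.6-fold higher number from compound 1 to compound 3 (0.22 log units; within the scatter) and a 1.0-fold higher number from compound 2 to compound 3 (0.01 log units; within the scatter), also stay within the scatter. With no measured step beyond the scatter, none is expected here. The expected step is a 1.1-fold lower number from compound 3 to compound 4 (0.03 log units; within the scatter). For compound 4 the estimate is 42000 nM, with an expected range of 22000 nM to 80000 nM.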

Compound 4, half-maximal inhibitory concentration: 78100 nM
Compound 4: middle estimate off by 1.9-fold (0.27 log units), on the low side; the measured number falls inside the stated range.
By their numbers in this assay, from the lowest: compounds 1, 2, 3 and 4 (each within the scatter of the next, the first and the last beyond it).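

In this assay, among these compounds, fluoro in place of hydrogen on an aromatic carbon, para to a large group, gives a step that stays within the scatter (a 1.7-fold higher number from compound 3 to compound 4 (0.24 log units; within the scatter)), so this direct change on the benzoyl side chain cannot be told from no change. (4-Fluorophenyl)carbonyl in place of 4-fluorophenyl on the saturated chain carbon bound to a sulfur also stays within the scatter (a 1.8-fold higher number from compound 2 to compound 4 (0.25 log units; within the scatter)), while the same group in place of 4-methylphenyl gives the first step beyond it, and a modest one (a 2.8-fold higher number from compound 1 to compound 4 (0.45 log units; beyond the scatter)). No measurement in hand gives a reason for these steps.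

Still open, from the compounds shown here alone, is whether an amine or a carboxylic acid on this aromatic carbon would give a step beyond the scatter from compound 3. Also open, going by these compounds, is how a longer chain on the sulfur would read against compound 1.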